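The source may hold more compounds than are shown below. What is called first, only, known or untested is meant among the compounds shown, and "the series" means these compounds.

Measured so far in an assay on HEK293 cells for inhibition of Steryl-sulfatase (Homo sapiens), tested at 1 uM; a higher number here means a stronger effect of the compound at the concentration tested, a lower number a weaker effect:
compound 1 `CCN(Cc1ccncc1)c1cccc(C(=O)N2CCc3ccc(OS(N)(=O)=O)cc3C2)c1` gives 52.8%;
compound 2 `CCCN(Cc1ccccc1)c1cccc(C(=O)N2CCc3ccc(OS(N)(=O)=O)cc3C2)c1` gives 67.4%.

Among the measured compounds shown here, compound 2 stands highest of the two numbers in this assay; the one step measured, a number 14.6 percentage points higher from compound 1 to compound 2 (beyond the scatter), is beyond the scatter but modest.

Compound 3 `CCCN(CCC)c1cccc(C(=O)N2CCc3ccc(OS(N)(=O)=O)cc3C2)c1` differs from compound 2 by ethyl in place of phenyl on a saturated chain carbon bound to a nitrogen on an aromatic ring. For the measured compounds named here, the single measured step bears on this only loosely: it changed the aromatic part of the substituent on the same nitrogen, whereas here the ring is lost altogether and nothing shows what that does. The step from compound 1 to compound 2 sets the scale of what this position has moved so far. A modest loss beyond the scatter is expected, a number 17.4 percentage points lower from compound 2 to compound 3 (beyond the scatter), with wide uncertainty. Compound 3 is therefore estimated at 50% in this assay, in the range 30% to 70%.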

Compound 3, a percentage reported as inhibition, at one concentration (the size of the read-out at that concentration, not a potency): 54.8%
Beside the measured number, compound 3's estimate is 4.8 percentage points below it, and the stated range covers the measured number.
By their numbers in this assay, from the lowest: compounds 1 and 3 (each within the scatter of the next); then compound 2.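

Replacing phenyl with ethyl, which turns benzyl(propyl)amino into dipropylamino, gives a number 12.6 percentage points lower from compound 2 to compound 3 (beyond the scatter) in this assay and shows that an aromatic ring on this chain is not needed for a clear read-out, although the number does fall without it. Dipropylamino in place of ethyl((pyridin-4-yl)methyl)amino gives a number 2 percentage points higher from compound 1 to compound 3 (within the scatter) so a substituent with no ring and one carrying a pyridin-4-yl group stand level here, and compound 2 alone stands apart from both. No measurement at hand accounts for either step.

The compounds shown leave open whether the higher number of compound 2 goes with the aromatic ring as such or with the size of the group, which a cyclohexyl in place of the phenyl or a longer chain such as hexyl would help separate. Also open, from the compounds shown here alone, is how a phenyl carrying fluorine or a methoxy group would read in this position.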